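This account rests on a few compounds, and the source may have more. Where it says the series, first, only, none or still open, it means among the compounds named here.

Measured in a functional assay on VCaP cells (Homo sapiens) for antiproliferative activity, read by CCK-8 assay, with a stated time of 6 days; a lower number here means a stronger inhibitor, a higher number a weaker inhibitor:
- compound 1 `C[C@@H](Cn1ccc(-c2ccc(C#N)c(Cl)c2)n1)NC(=O)c1ccccc1`: "not determined" (no result reported)
- compound 2 `Cc1ccnc(N[C@@H](C)Cn2ccc(-c3ccc(C#N)c(Cl)c3)n2)n1`: 850 nM

Among the compounds with values here, compound 2, at 850 nM, holds the only number so far, since compound 1 has no reported result. Within the data shown here, that leaves nothing to rank it against and no measured step to show how much this assay responds to a structural change.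

Compound 3 `C[C@@H](Cn1ccc(-c2ccc(C#N)c(Cl)c2)n1)Nc1ncnc2nc[nH]c12` keeps the core of compound 2 but changes the group on the amine nitrogen: a group of 9 heavy atoms (5 carbon, 4 nitrogen; one five-membered aromatic ring with 2 hetero atoms, one six-membered aromatic ring with 2 hetero atoms) in place of a group of 7 heavy atoms (5 carbon, 2 nitrogen; one six-membered aromatic ring with 2 hetero atoms), on an amine nitrogen. The single ring is thus replaced by a larger group with a five-membered and a six-membered aromatic ring.

With so little data, only a small shift is expected, perhaps a slight weakening that may not exceed the usual scatter. The expected step is a 1.4-fold higher number from compound 2 to compound 3 (0.15 log units; within the scatter). For compound 3 the estimated value is 1200 nM, with an expected range of 300 nM to 5000 nM.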

Compound 3, half-maximal inhibitory concentration: 640 nM
For compound 3 the middle estimate is 1.9-fold (0.27 log units) above the measured one, and the stated range covers the measured number.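

In this assay, within the data shown here, exchanging the group on the amine nitrogen gives a 1.3-fold lower number from compound 2 to compound 3 (0.12 log units; within the scatter), the first measured step at this position, and the two compounds cannot be told apart. The 4-methylpyrimidin-2-yl group can therefore be replaced by a larger group with a five-membered and a six-membered aromatic ring, which also brings a hydrogen-bond donor, without a change beyond the scatter. No measurement shown here explains why the two groups read alike.

From the compounds shown here alone, with a single readable step, it remains open how far this position tolerates change, and compound 1 offers no comparison without a number. A phenyl ring, an ethyl chain or a free amine on this nitrogen could show whether any group here moves the activity beyond the scatter.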